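The source may hold more compounds than are shown below. What is called first, only, known or untested is meant among the compounds shown, and "the series" means these compounds.

Compound 3 `CC(C)N(C)/N=N/c1ccc(C(=O)O)cc1` gives 0.34 in a physicochemical assay for lipophilicity, in phosphate buffer, measured as octanol-water partition, at pH 7.4; a higher number here means a more lipophilic compound, a lower number a more polar compound. Among the three measured compounds this is the second highest number: compound 1 `C=CCN(C)/N=N/c1ccc(C(=O)O)cc1` gives 0.32 in this assay, and a number 0.02 log units higher from compound 1 to compound 3 (within the scatter), whereas compound 2 `CCCCCN(C)/N=N/c1ccc(C(=O)O)cc1` gives 1.49 in this assay, and a number 1.15 log units lower from compound 2 to compound 3 (beyond the scatter). Compound 4 `CCCN(C)/N=N/c1ccc(C(=O)O)cc1` differs from compound 3 in one place: propyl in place of isopropyl on an amine nitrogen. Going by the values given here, of the measured steps, a number 0.02 log units higher from compound 1 to compound 3 (within the scatter) is the closest precedent, as it too exchanges one group of three carbon atoms for another on the amine nitrogen without changing the count. The large steps of a number 1.17 log units higher from compound 1 to compound 2 (beyond the scatter) and a number 1.15 log units lower from compound 2 to compound 3 (beyond the scatter) each add or remove chain atoms, which the change from compound 3 to compound 4 does not. On that basis no step beyond the scatter is expected in this assay, at most a small rise. Compound 4 is therefore expected to give 0.55 in this assay, with a range from 0.25 to 0.9. The expected step is a number 0.21 log units higher from compound 3 to compound 4 (within the scatter), which lies within the scatter.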

Compound 4, distribution coefficient: 0.46
Compound 4: the middle estimate sits 0.09 log units above what was measured; the measured number falls inside the stated range.
By their numbers in this assay, from the lowest: compounds 1, 3 and 4 (each within the scatter of the next); then compound 2.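

In this assay propyl in place of isopropyl on the amine nitrogen, the same atoms joined differently, gives a number 0.12 log units higher from compound 3 to compound 4 (within the scatter) and so does not separate these two arrangements of the chain. Ethyl in place of vinyl on the saturated chain carbon bound to the amine nitrogen gives a number 0.14 log units higher from compound 1 to compound 4 (within the scatter) and is equally unresolved, while hydrogen in place of ethyl, three bonds along the chain from the amine nitrogen, gives a number 1.03 log units lower from compound 2 to compound 4 (beyond the scatter) and is large. All the large steps at this position now run to or from the pentyl chain of compound 2, while allyl, isopropyl and propyl stay within the scatter of one another.

As far as these compounds go, whether a butyl chain, a cyclopropyl group or a propyl chain ending in a hydroxyl group would stay with these three or move towards compound 2 remains open. No measured evidence offers a reason for any of these numbers.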